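The source may hold more compounds than are shown below. What is called first, only, known or untested is meant among the compounds shown, and "the series" means these compounds.

In a functional assay on RAW264.7 cells (Mus musculus), read by Griess assay, with a stated time of 15 min (on this read-out lower numbers stand for stronger inhibition and higher numbers for weaker inhibition), compound 1 (`C/C=C(\C)C(=O)O[C@H]1C[C@@H](C)[C@]2(O)CC[C@](C)(/C=C3/OC(=O)C(CO)=C31)O2`) gives 5700 nM, the lowest of the three numbers. Compound 2 (`C[C@@H]1C[C@H](O)C2=C(CO)C(=O)O/C2=C/[C@@]2(C)CC[C@]1(O)O2`) gives 24700 nM and compound 3 (`CO[C@]12CC[C@](C)(/C=C3/OC(=O)C(CO)=C3[C@@H](O)C[C@H]1C)O2`) gives 28100 nM. Compound 4 (`C/C=C(\C)C(=O)O[C@H]1C[C@@H](C)[C@]2(O)CC[C@](C)(/C=C3/OC(=O)C(COC(C)=O)=C31)O2`) differs from compound 1 by acetyl in place of hydrogen on an oxygen on a saturated carbon, which turns hydroxymethyl to acetoxymethyl. Among the compounds with values here, two measured steps bear on this only loosely, as neither changes the hydroxymethyl. Removing an acyl group from another oxygen gave a 4.3-fold higher number from compound 1 to compound 2 (0.64 log units; beyond the scatter), while placing methyl on a further oxygen gave a 1.1-fold higher number from compound 2 to compound 3 (0.06 log units; within the scatter). No step beyond the scatter is therefore expected in this assay, and no direction is favoured strongly. The expected change is a 1.1-fold lower number from compound 1 to compound 4 (0.06 log units; within the scatter). The estimate for compound 4 is 5000 nM, with an expected range of 2000 nM to 12000 nM.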

Compound 4, half-maximal inhibitory concentration: 2000 nM
Compound 4: middle estimate off by 2.5-fold (0.40 log units), on the high side; low and high end bracket the measured number.
By their numbers in this assay, from the lowest: compound 4; then compound 1; then compounds 2 and 3 (each within the scatter of the next).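

In this assay, within the data shown here, acetyl on the hydroxymethyl oxygen gives a 2.9-fold lower number from compound 1 to compound 4 (0.45 log units; beyond the scatter), the first change at this position. Among these compounds, the free hydroxy of compound 1 is therefore not needed for inhibition here, and the acetoxymethyl form of the shared core gives the lowest number so far. Nothing measured on these compounds accounts for the shift.

From the compounds shown here alone, whether this step belongs to acetyl specifically stays open, since a longer acyl chain such as butanoyl or a methyl ether on this oxygen would test that. Going by these compounds, how an amine or a carboxylic acid in place of the hydroxy would read also remains unknown.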